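Shifting a Chlorine on the Aryl Group at the Ring Nitrogen

A few compounds are considered here, and "the series" means these few. Any claim that something is new, unique, unknown or untested is made for them only; others in the source may bear on it.

Three compounds share one core and differ only in the aryl group on the aromatic nitrogen. Compound 1 `COc1cccc(-n2cc(COc3cccc(NC(=O)Nc4ccc(Cl)c(C(F)(F)F)c4)c3)nn2)c1` gives 1310 nM in a functional assay on HepG2 cells (Homo sapiens) for inhibition, read by MTT assay, with a stated time of 72 h; a higher number here means a weaker inhibitor, a lower number a stronger inhibitor. Compound 2 `CCc1ccc(-n2cc(COc3cccc(NC(=O)Nc4ccc(Cl)c(C(F)(F)F)c4)c3)nn2)cc1` gives 1950 nM in this assay, and compound 3 `O=C(Nc1cccc(OCc2cn(-c3ccccc3Cl)nn2)c1)Nc1ccc(Cl)c(C(F)(F)F)c1` gives 1960 nM in this assay. Compound 3 has the highest of the three numbers, yet the steps of a 1.5-fold higher number from compound 1 to compound 3 (0.17 log units; within the scatter) and a 1.0-fold higher number from compound 2 to compound 3 (0.00 log units; within the scatter) lie within the scatter, as does a 1.5-fold higher number from compound 1 to compound 2 (0.17 log units; within the scatter); on these data the three cannot be told apart.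

Compound 4 `O=C(Nc1cccc(OCc2cn(-c3cccc(Cl)c3)nn2)c1)Nc1ccc(Cl)c(C(F)(F)F)c1` is the next step: 3-chlorophenyl in place of 2-chlorophenyl on an aromatic nitrogen. Every step measured so far at this place, from a 3-methoxyphenyl to a 4-ethylphenyl or a 2-chlorophenyl, left the number within the scatter, and the set holds no earlier move of a chlorine within that ring to draw on. The expected step is therefore none beyond the scatter, a 1.0-fold lower number from compound 3 to compound 4 (0.01 log units; within the scatter). Compound 4 is expected to give 1900 nM in this assay, with a range from 900 nM to 4000 nM.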

Compound 4, half-maximal inhibitory concentration: 2020 nM
Compound 4: the middle estimate sits 1.1-fold (0.03 log units) below what was measured, within the range that was stated.
By their numbers in this assay, from the lowest: compounds 1, 2, 3 and 4 (each within the scatter of the next).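

Moving the chlorine within the ring, with 3-chlorophenyl in place of 2-chlorophenyl on the aromatic nitrogen, gives (a 1.0-fold higher number from compound 3 to compound 4 (0.01 log units; within the scatter)) in this assay, so the two chlorine positions shown cannot be told apart in this assay. The same holds for the exchange of a 4-ethylphenyl for this 3-chlorophenyl (a 1.0-fold higher number from compound 2 to compound 4 (0.02 log units; within the scatter)) and for chloro in place of methoxy on an aromatic carbon at the same ring position (a 1.5-fold higher number from compound 1 to compound 4 (0.19 log units; within the scatter)), which extends the flat picture at this position to all four compounds. Nothing available explains why these numbers stay together.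

On these data alone, whether a 4-chlorophenyl or an unsubstituted phenyl would give a number in the same range remains open. So does whether an amine or a carboxylic acid on this ring would produce a step beyond the scatter.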